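Acyloxy replacement of a para propyl group on the styryl ring

The source may report more compounds than this note shows. Statements on the series, on what has been measured and on what is new or still open speak of the compounds shown alone.

Of the compounds shown here, three sharing one core have been measured in an assay on membranes from brain for displacement of a labelled ligand from Neuronal acetylcholine receptor; alpha4/beta2 (Rattus norvegicus), with a stated time of 3 h; a higher number here means a weaker inhibitor, a lower number a stronger inhibitor. Compound 1 `C(=C1\CCCN=C1c1cccnc1)\c1ccccc1` gives 850 nM. Compound 2 `FC(F)Oc1ccc(/C=C2\CCCN=C2c2cccnc2)cc1` gives 1160 nM, and compound 3 `CCCc1ccc(/C=C2\CCCN=C2c2cccnc2)cc1` gives 890 nM. The three steps between them all stay within the usual scatter: a 1.4-fold higher number from compound 1 to compound 2 (0.14 log units; within the scatter), a 1.0-fold higher number from compound 1 to compound 3 (0.02 log units; within the scatter) and a 1.3-fold lower number from compound 2 to compound 3 (0.12 log units; within the scatter). Compound 3 therefore cannot be set apart from either neighbour; its nearest is compound 1 and its furthest compound 2, and neither gap is meaningful.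

Compound 4 `CC(C)(C)C(=O)Oc1ccc(/C=C2\CCCN=C2c2cccnc2)cc1` differs from compound 3 by ((tert-butyl)carbonyl)oxy in place of propyl on an aromatic carbon. The bearing steps are those that changed the same aromatic carbon: hydrogen to difluoromethoxy, hydrogen to propyl, and difluoromethoxy to propyl, each within the scatter. The group entering compound 4 has not been tested in this series, and the nearest oxygen-linked example, difluoromethoxy in compound 2, moved nothing. On that basis compound 4 is expected to show a step of a 1.1-fold higher number from compound 3 to compound 4 (0.05 log units; within the scatter) in this assay, that is no change beyond the scatter. Compound 4 is accordingly estimated at 1000 nM, with a range from 400 nM to 2800 nM that allows for the untested group.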

Compound 4, inhibition constant: 830 nM
For compound 4 the middle estimate is 1.2-fold (0.08 log units) above the measured one; the measured number falls inside the stated range.
By their numbers in this assay, from the lowest: compounds 4, 1, 3 and 2 (each within the scatter of the next).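

In this assay, the aromatic carbon para to a large group takes ((tert-butyl)carbonyl)oxy in place of propyl with a 1.1-fold lower number from compound 3 to compound 4 (0.03 log units; within the scatter), and the same group gives a 1.0-fold lower number from compound 1 to compound 4 (0.01 log units; within the scatter) in place of hydrogen, while (tert-butyl)carbonyl in place of difluoromethyl on the oxygen gives a 1.4-fold lower number from compound 2 to compound 4 (0.15 log units; within the scatter). The earlier compounds shown here had covered only hydrogen, propyl and difluoromethoxy at this carbon, whereas the entering group brings a carbonyl, two oxygens and hydrogen-bond acceptors, and still cannot be told apart from any of them. The four compounds thus span groups from hydrogen to a branched ester at this carbon without a step beyond the scatter, and nothing at hand bears on why the numbers stay together.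

As far as these compounds go, whether an amine, a carboxylic acid or a hydroxyl on this carbon would stay with these four numbers remains open, as does whether a longer chain or a ring-bearing ester would. From the compounds shown here alone, it is also open whether any group elsewhere on the shared core would give a step beyond the scatter.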